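The source may hold more compounds than are shown below. What is called first, only, known or untested is meant among the compounds shown, and "the series" means these compounds.

In a functional assay on U-937 cells (Homo sapiens) for cytotoxicity, read by MTT assay, with a stated time of 24 h (a higher number here means a weaker inhibitor, a lower number a stronger inhibitor), the compounds measured so far are:

compound 1, `CCCCCCCCCCn1cc(-c2nc3ccccc3cc2CC)nn1`: 12.7 ug/mL
compound 2, `CCCCCc1cc2ccccc2nc1-c1cn(CCC(F)(F)C(F)(F)C(F)(F)C(F)(F)C(F)(F)C(F)(F)C(F)(F)C(F)(F)F)nn1`: > 100 ug/mL
compound 3, `CCCCc1cc2ccccc2nc1-c1cn(-c2ccc(F)cc2)nn1`: 66.2 ug/mL

Where compound 2 stands: its result in this assay is a limit only, not a number, the value standing as > 100 ug/mL. Compound 2 thus sits at the limit of > 100 ug/mL in this assay, at which 1 of the 3 values shown sits, and no number is known for it.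

Compound 4, `CCCCc1cc2ccccc2nc1-c1cn(CCC(F)(F)C(F)(F)C(F)(F)C(F)(F)C(F)(F)C(F)(F)C(F)(F)C(F)(F)F)nn1`, is not yet measured. It differs from compound 2 by hydrogen in place of methyl on a saturated chain carbon, four bonds along the chain from an aromatic carbon; in words, hydrogen in place of methyl on a saturated chain carbon, four bonds along the chain from an aromatic carbon. Within the data shown here, no step between two measured compounds is recorded for this assay, so the size of the step is taken from the small scale of the change alone: the expectation is for no shift beyond the usual scatter, in either direction, and most likely a second limit.

For compound 4 the estimated value is 100 ug/mL, with a range from 40 ug/mL to 250 ug/mL. The step this estimate implies, a number no higher from compound 2 to compound 4 (the limit leaves the size open), is expected to be none beyond the scatter.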

Compound 4, half-maximal inhibitory concentration: 59.1 ug/mL
For compound 4 the middle estimate is 1.7-fold (0.23 log units) above the measured one; low and high end bracket the measured number.
By their numbers in this assay, from the lowest: compound 1; then compounds 4 and 3 (each within the scatter of the next). At a limit, above all of these: compound 2.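

Compound 2 is a limit, not a number: the limit of > 100 ug/mL in this assay, at which 1 of the 4 values shown sits. In this assay, among these compounds, hydrogen in place of methyl on a saturated chain carbon, four bonds along the chain from an aromatic carbon, gives the only readable pair at this position, with an at least 1.6-fold lower number from compound 2 to compound 4 (0.22 log units; that floor lies within the scatter). The limit leaves the true size of this step open, so the pair shows that compound 4 reads as a number but does not establish a change beyond the scatter.

The compounds shown leave open whether an amine, a carboxylic acid or a longer chain at this position would move the number in this assay. Among the compounds shown here, no pair here has numbers at both ends for a change at this position alone, so no trend with chain length can be read.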